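Vinyl Enters the Benzamide Ring of Compound 1

The compounds below may be only part of what the source reports. "The series", "measured", "known", "first", "only" and "open" are said of these compounds alone.

Compound 1 `O=C(NCN1CCC(c2cccc[n+]2[O-])CC1)c1ccccc1` was tested in a functional assay on HEK293 cells for agonist activity at D(4) dopamine receptor (Homo sapiens), read by FLIPR (on this read-out higher numbers stand for an effect only at larger amounts of compound and lower numbers for an effect already at smaller amounts), where compound 1 gives 532 nM. Among the three numbers measured, this is the second highest. Compound 3 `CC(C)Oc1cccc(NC(=O)CN2CCC(c3cccc[n+]3[O-])CC2)c1` gives 555 nM in this assay, a value within the scatter of that of compound 1. Compound 2 `Cc1cccc(Cl)c1NC(=O)CN1CCC(c2ccccn2)CC1` gives 60 nM in this assay, the lowest of the three and beyond the scatter from compound 1. Compound 4 `C=Cc1cccc(C(=O)NCN2CCC(c3cccc[n+]3[O-])CC2)c1` has not been measured; it differs from compound 1 by vinyl in place of hydrogen on an aromatic carbon, a vinyl in place of hydrogen on an aromatic carbon. For the measured compounds named here, no measured pair shows this change, so no step is known for it. A modest step toward lower numbers is expected, a 1.3-fold lower number from compound 1 to compound 4 (0.12 log units; within the scatter), though nothing beyond the scatter is assured. Compound 4 is estimated at 400 nM, with a range from 150 nM to 1200 nM.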

Compound 4, half-maximal effective concentration: 68 nM
The estimate for compound 4 lay 5.9-fold (0.77 log units) above the measured number; measured number below the stated range.
By their numbers in this assay, from the lowest: compounds 2 and 4 (each within the scatter of the next); then compounds 1 and 3 (each within the scatter of the next).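

On the six-membered aromatic ring of carbon only, at the carbon meta to a large group, vinyl in place of hydrogen gives a 7.8-fold lower number from compound 1 to compound 4 (0.89 log units; beyond the scatter) in this assay. This is the first single-place step among the compounds shown, and it shows that this position responds to a small group with no ring and no net charge. No measurement shown accounts for the size of this step. As far as these compounds go, whether ethyl or ethynyl at this carbon would give a similar number remains open. So does the outcome with an amine or a carboxylic acid there.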